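The source may hold more compounds than are shown below. What is called first, only, known or untested is meant among the compounds shown, and "the series" means these compounds.

Compound 2, `Cc1ccccc1N1C(=O)/C(=C/c2ccc(O)c(Cl)c2)S/C1=N\CCO`, is the starting point. In a physicochemical assay for solubility, measured as kinetic solubility (on this read-out lower numbers stand for lower solubility and higher numbers for higher solubility), compound 2 gives > 250000 nM, which is a limit of the assay rather than a number. Among the measured compounds shown here, the only other value of its kind is the limit of > 250000 nM in this assay, at which 1 of the 3 values shown sits, so compound 2 is the one compound whose solubility lies beyond what the assay counts.

Compound 4, `CCC/N=C1\S/C(=C\c2ccc(O)c(Cl)c2)C(=O)N1c1ccccc1C`, differs from compound 2 in one place: methyl in place of hydroxy on a saturated chain carbon, two bonds along the chain from a double-bonded nitrogen. The same kind of chain already appears in compound 1, `CCC/N=C1\S/C(=C\c2ccc(O)cn2)C(=O)N1c1ccccc1C`, and compound 3, `CCC/N=C1\S/C(=C\c2ccc(O)c(C)c2)C(=O)N1c1ccccc1C`. In this assay compound 1 gives 110000 nM, and compound 3 gives 78000 nM. For the measured compounds named here, the one measured step between them, a 1.4-fold lower number from compound 1 to compound 3 (0.15 log units; within the scatter), changes a ring and not the chain, so no measured step bears directly on the change from compound 2 to compound 4.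

What the numbers do show is that both compounds carrying the propyl chain sit below the limit of the assay. Compound 4 carries the same chain on the same core, so it is expected to fall into the range of compound 1 and compound 3 rather than beyond the limit. The estimate for compound 4 is 80000 nM, with a range from 30000 nM to 200000 nM. This means an expected step of an at least 3.1-fold lower number from compound 2 to compound 4 (0.49 log units; beyond the scatter).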

Compound 4, solubility: 79000 nM
Compound 4: the middle estimate sits 1.0-fold (0.01 log units) above what was measured; the range from low to high includes it.
By their numbers in this assay, from the lowest: compounds 3, 4 and 1 (each within the scatter of the next). At a limit, above all of these: compound 2.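

Among the compounds shown here, compound 2 and compound 4 differ only in 2-hydroxyethyl against propyl, so this pair gives the first reading of a change at this chain, and in this assay it shows an at least 3.1-fold lower number from compound 2 to compound 4 (0.50 log units; beyond the scatter). The size of that step has no upper end, as compound 2 stands at a limit of the assay and not at a number: the limit of > 250000 nM in this assay, at which 1 of the 4 values shown sits. With propyl held in place, the changes on the aromatic ring stay small by comparison, with a 1.0-fold higher number from compound 3 to compound 4 (0.01 log units; within the scatter) and a 1.4-fold lower number from compound 1 to compound 4 (0.14 log units; within the scatter), so among the compounds shown only the chain change goes beyond the scatter.

Going by these compounds, how far past the limit compound 2 really lies stays open, and so does the full size of the step from hydroxy to methyl at this place. Also open, on these data alone, is whether an amine or a carboxylic acid at the end of the chain, or a longer chain carrying the same hydroxy, would give a number in the range of compound 4 or reach the limit as compound 2 does.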